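Shortening an ethyl group to methyl

The source may hold more compounds than are shown below. What is called first, only, known or untested is meant among the compounds shown, and "the series" means these compounds.

Going by the values given here, compound 3 (`CCc1ccc(OCc2ccc(C(=O)Nc3ccccc3N)cc2)cc1`) gives 6420 nM in a functional assay on A549 cells (Homo sapiens) for antiproliferative activity, read by CCK-8 assay, with a stated time of 72 h (a lower number here means a stronger inhibitor, a higher number a weaker inhibitor), and sits at the low end of the numbers known so far. Compound 2 (`Nc1ccccc1NC(=O)c1ccc(COc2ccccc2)cc1`) gives 6760 nM and shares that low end, for the step of a 1.1-fold lower number from compound 2 to compound 3 (0.02 log units; within the scatter) lies within the scatter and the two cannot be ranked. Compound 1 (`Nc1ccccc1NC(=O)c1ccc(COc2ccc(Br)cc2)cc1`) stands apart at 24400 nM on the higher side.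

Compound 4 (`Cc1ccc(OCc2ccc(C(=O)Nc3ccccc3N)cc2)cc1`) differs from compound 3 in one place: ethyl becomes methyl, which is hydrogen in place of methyl on a saturated chain carbon bound to an aromatic carbon. The closest evidence is the step of a 1.1-fold lower number from compound 2 to compound 3 (0.02 log units; within the scatter) in which ethyl replaced hydrogen on an aromatic carbon. Compound 4 carries methyl where compound 2 has hydrogen and compound 3 has ethyl, and those two neighbours show no gap beyond the scatter. The larger steps of a 3.6-fold lower number from compound 1 to compound 2 (0.56 log units; beyond the scatter) and a 3.8-fold lower number from compound 1 to compound 3 (0.58 log units; beyond the scatter) are modest, but both remove bromo, which plays no part in this change. No shift in either direction is therefore expected. The estimate amounts to a 1.0-fold higher number from compound 3 to compound 4 (0.01 log units; within the scatter) and this step is expected to stay within the scatter. For compound 4 the expected value is 6600 nM with an estimated range from 3500 nM to 12500 nM as its likely span.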

Compound 4, half-maximal inhibitory concentration: 5430 nM
For compound 4 the middle estimate is 1.2-fold (0.08 log units) above the measured one, within the range that was stated.
By their numbers in this assay, from the lowest: compounds 4, 3 and 2 (each within the scatter of the next); then compound 1.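

In this assay, trimming ethyl to methyl gives a 1.2-fold lower number from compound 3 to compound 4 (0.07 log units; within the scatter), and putting methyl in place of hydrogen on the aromatic carbon gives a 1.2-fold lower number from compound 2 to compound 4 (0.10 log units; within the scatter). With methyl now added, three small substituents at this spot, hydrogen, methyl and ethyl, all sit within the scatter of one another, so this short series shows no dependence on the length of the alkyl group and no ranking among compounds 2, 3 and 4. Bromo remains the only group that stands apart, as the modest step of a 4.5-fold lower number from compound 1 to compound 4 (0.65 log units; beyond the scatter) shows, and nothing measured here offers an explanation for that gap or for the flat response among the other three.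

The compounds shown leave open whether a longer chain such as propyl or butyl, or a different kind of group such as an amine or a carboxylic acid, would stay at this same level. They also leave open whether the gap belongs to bromo alone or would also appear with another halogen such as chloro or fluoro.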